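Swapping the benzoyl thioester for an acetyl thioester

The source may hold more compounds than are shown below. What is called first, only, known or untested is meant among the compounds shown, and "the series" means these compounds.

Compound 1, `CCOC(=O)[C@@H](N)CCC(=O)NCCSC(=O)c1ccccc1`, is an amino-acid ethyl ester carrying a thioester of benzoic acid at the far end of its chain. In an ADME assay on isolated protein for metabolic stability, with Cocaine esterase (Homo sapiens) as the target (a higher number here means that the compound lasts longer, a lower number that the compound disappears faster), compound 1 gives 0.167 h. Compound 2, `CCCCOC(=O)[C@@H](N)CCC(=O)NCCSC(=O)c1ccccc1`, has a butyl ester in place of the ethyl ester, and in this assay compound 2 gives 0.167 h. That single change, ethyl in place of hydrogen on a saturated chain carbon two bonds along the chain from an oxygen next to a carbonyl group, produced no change at the digits printed from compound 1 to compound 2 (within the scatter). Compound 3, `CCOC(=O)[C@@H](N)CCC(=O)NCCSC(C)=O`, differs from compound 1 at the other end of the molecule: methyl in place of phenyl on a carbonyl carbon. Among the measured compounds shown here, the only measured step concerns a different part of the molecule and left the half-life unchanged, so no step beyond the scatter is expected, a 1.1-fold lower number from compound 1 to compound 3 (0.05 log units; within the scatter). Compound 3 is therefore expected to give about 0.15 h, within a range of 0.05 h to 0.45 h.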

Compound 3, half-life in the Cocaine esterase assay: 0.167 h
For compound 3 the middle estimate is 1.1-fold (0.05 log units) below the measured one; the measured number falls inside the stated range.
By their numbers in the Cocaine esterase assay, from the lowest: compounds 1, 2 and 3 (each within the scatter of the next).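

In the Cocaine esterase assay methyl in place of phenyl on a carbonyl carbon gave no change at the digits printed from compound 1 to compound 3 (within the scatter), with compound 1 at 0.167 h and compound 3 at 0.167 h, and so removed the aromatic ring with no visible effect on the half-life. The earlier step had tested only the ester end of the molecule, whereas this one shows the same flat reading at the thioester end; in a physicochemical assay for acid dissociation, using potentiometric titration, at pH 2, the same change gave a number 0.09 log units higher from compound 1 to compound 3 (within the scatter) as well, with compound 1 at 8.85 and compound 3 at 8.94. Nothing available explains why the half-life holds level through this change.

As far as these compounds go, whether a tert-butyl group on this carbonyl carbon would move the half-life remains open. So does the outcome of an amide in place of the thioester, or of a carboxylic acid in place of the ethyl ester.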